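This account rests on a few compounds, and the source may have more. Where it says the series, first, only, none or still open, it means among the compounds named here.

Compound 2 `COc1cc(-c2cc(/C=C/C(=O)c3ccc(N)cc3)[nH]n2)cc(OC)c1OC` shows the highest number of the three compounds measured in a functional assay on MDA-MB-435 cells (Homo sapiens) for cytotoxicity, read by sulforhodamine B assay, with a stated time of 48 h, tested at 1 uM (a lower number here means a stronger effect, a higher number a weaker effect of the compound at the concentration tested), where compound 2 gives 88%. Compound 1 `COc1ccc(-c2cc(/C=C/C(=O)c3ccc(N)cc3)[nH]n2)cc1` gives 85%, a value within the scatter of compound 2. Compound 3 `COc1ccc(C(=O)/C=C/c2cc(-c3cc(OC)c(OC)c(OC)c3)n[nH]2)cc1OC` gives 70%; the step of a number 18 percentage points lower from compound 2 to compound 3 (beyond the scatter) puts 3,4-dimethoxyphenyl in place of 4-aminophenyl on a carbonyl carbon. Compound 4 `COc1ccc(C(=O)/C=C/c2cc(-c3cc(OC)c(OC)c(OC)c3)n[nH]2)cc1` differs from compound 2 by methoxy in place of amino on an aromatic carbon, turning 4-aminophenyl into 4-methoxyphenyl. For the measured compounds named here, the only step that bears on this change is a number 18 percentage points lower from compound 2 to compound 3 (beyond the scatter), which also removed the amino group and brought in methoxy, so a modest drop is expected here too. For compound 4 the expected value in this assay is 74%, ranging from 60% to 88%. That estimate means an expected step of a number 14 percentage points lower from compound 2 to compound 4 (beyond the scatter).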

Compound 4, a percentage reported as activity, at one concentration (the size of the read-out at that concentration, not a potency): 92%
Estimate against measurement, compound 4: 18 percentage points below, and the stated range ends below it.
By their numbers in this assay, from the lowest: compound 3; then compounds 1, 2 and 4 (each within the scatter of the next).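

Methoxy in place of amino on this aromatic carbon gives a number 4 percentage points higher from compound 2 to compound 4 (within the scatter), so in this assay the two groups cannot be told apart here, and losing the amino group does not account for the lower number of compound 3. That lower number instead goes with the second methoxy of 3,4-dimethoxyphenyl: hydrogen in its place gives a number 22 percentage points higher from compound 3 to compound 4 (beyond the scatter). No measurement at hand explains either step. On these data alone, whether a hydroxyl group, a chlorine atom or a carboxylic acid at this place would match amino and methoxy stays open. So does whether a second methoxy would lower the number on other versions of the core.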